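The source may report more compounds than this note shows. Statements on the series, on what has been measured and on what is new or still open speak of the compounds shown alone.

Measured so far:

Compound 1, `COc1cc(OC)c(OC)cc1/C=C/COC(=O)/C=C/c1ccc(OC)c(OC)c1`, gives 100% in a functional assay on the whole organism (strain Kunming) with Mus musculus as the target, with a stated time of 0.5 h, at a dose of 100 mg/kg by the intraperitoneal route; on this read-out lower numbers stand for a stronger effect and higher numbers for a weaker effect at the one dose given.
Compound 2, `COc1cc(OC)c(OC)cc1/C=C/COC(=O)/C=C/c1c(OC)ccc(OC)c1OC`, gives 100% in this assay.
Compound 3, `COc1cc(OC)c(OC)cc1/C=C/COC(=O)/C=C/c1cc(OC)c(OC)c(OC)c1OC`, gives 100% in this assay.

All three measured compounds share the same core and return the same reading in this assay. Compound 3 therefore stands level with compounds 1 and 2 at the digits reported; its nearest neighbour is compound 1 and its furthest is compound 2, and in both cases there is no change at the digits reported, so the gaps lie within the usual scatter. No ordering among the three can be drawn from these numbers.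

Compound 4, `COc1cc(OC)c(OC)cc1/C=C/COC(=O)/C=C/c1cc(OC)c(OC)c(OC)c1`, has not yet been measured. It differs from compound 3 in a single place: hydrogen in place of methoxy on an aromatic carbon. Among the compounds with values here, because compounds 1, 2 and 3 all return 100%, nothing measured so far points to any movement in this assay, and no step beyond the scatter is expected in either direction. The step from compound 3 to compound 4 is expected to be no change at the digits printed from compound 3 to compound 4 (within the scatter). Compound 4 is estimated to give 100% in this assay, within a range from 85% to 105%.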

Compound 4, a percentage reported as activity, at one dose (the size of the read-out at that dose, not a potency): 100%
Beside the measured number, compound 4's estimate shows no gap at the digits printed; measured number inside the range.
By their numbers in this assay, from the lowest: compounds 1, 2, 3 and 4 (each within the scatter of the next).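

Taking the methoxy off the aromatic carbon ortho to a large group and leaving hydrogen there gives no change at the digits printed from compound 3 to compound 4 (within the scatter) in this assay and so shows that this one position can lose its methoxy without moving the reading. Methoxy in place of hydrogen on an aromatic carbon gives no change at the digits printed from compound 1 to compound 4 (within the scatter) and so adds a second single-place change that leaves the reading unmoved. No outside measurement on these compounds helps to interpret these flat results.

As far as these compounds go, whether an amine, a carboxylic acid or a hydroxy group on this same aromatic carbon would shift the reading remains open. With every step here lying within the scatter, the compounds shown also leave open which part of the shared core, if any, can move the reading at all.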